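This account rests on a few compounds, and the source may have more. Where it says the series, first, only, none or still open, it means among the compounds named here.

Measured in a functional assay on HepG2 cells (Homo sapiens) for antiproliferative activity, read by MTT assay, with a stated time of 48 h; on this read-out higher numbers stand for weaker inhibition and lower numbers for stronger inhibition:
- Compound 1 `O=[N+]([O-])c1cc(C(F)(F)F)cc([N+](=O)[O-])c1Oc1ccccc1/C=N/OCc1ccc(Cl)cc1Cl`: 1020 nM
- Compound 2 `O=[N+]([O-])c1cc(C(F)(F)F)cc([N+](=O)[O-])c1Oc1ccc(Br)cc1/C=N\OCc1ccccc1F`: 890 nM
- Compound 3 `O=[N+]([O-])c1cc(C(F)(F)F)cc([N+](=O)[O-])c1Oc1c(Br)cc(Br)cc1/C=N\OCc1ccccc1F`: 1100 nM

Compound 3 stands within the scatter of both compound 1 and compound 2. Compound 4 `O=[N+]([O-])c1cc(C(F)(F)F)cc([N+](=O)[O-])c1Oc1c(Br)cc(Br)cc1/C=N/OCc1ccc(Cl)cc1Cl` differs from compound 3 by a group of 12 heavy atoms (8 carbon, 1 nitrogen, 1 oxygen, 2 chlorine; one six-membered aromatic ring of carbon only) in place of a group of 11 heavy atoms (8 carbon, 1 nitrogen, 1 oxygen, 1 fluorine; one six-membered aromatic ring of carbon only), on an aromatic carbon. Going by the values given here, no measured step isolates this change. Among the compounds with values here, the one measured step, a 1.2-fold higher number from compound 2 to compound 3 (0.09 log units; within the scatter), concerns a bromo in place of hydrogen and stays within the scatter. Compound 1 already carries the entering group and gives 1020 nM. In this assay, the expected step is a 1.0-fold lower number from compound 3 to compound 4 (0.02 log units; within the scatter), and none beyond the scatter is expected. The estimate for compound 4 is 1050 nM, with an expected range of 550 nM to 2000 nM.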

Compound 4, half-maximal inhibitory concentration: 1050 nM
The estimate for compound 4 equals the measured number at the digits printed; low and high end bracket the measured number.
By their numbers in this assay, from the lowest: compounds 2, 1, 4 and 3 (each within the scatter of the next).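

In this assay, going by these compounds alone, the group of 12 heavy atoms with 2 chlorine, in place of the group of 11 heavy atoms with 1 fluorine, gives a 1.0-fold lower number from compound 3 to compound 4 (0.02 log units; within the scatter), the first measured step at this aromatic carbon. With the two bromo groups present, this exchange therefore stays within the scatter. No evidence bears on the reason for this result. The compounds shown leave open whether the same exchange stays within the scatter without the two bromo groups. They also leave open what an amine or a carboxylic acid on the entering ring would give.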